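Moving one methyl group: what happens to oral exposure?

The source may report more compounds than this note shows. Statements on the series, on what has been measured and on what is new or still open speak of the compounds shown alone.

Measured in an ADME assay on the whole organism for pharmacokinetics, with Rattus norvegicus as the target, with a stated time of 6 h, at a dose of 10 mg/kg by the oral route; on this read-out lower numbers stand for lower exposure and higher numbers for higher exposure at the dose given:
- Compound 1 `Cc1cn2c(-c3cn[nH]c3)cnc2c(Nc2cc(Cn3cccn3)ns2)n1`: "not determined" (no result reported)
- Compound 2 `Cc1cn2c(-c3cn[nH]c3)cnc2c(Nc2cc(Cc3ncccc3C)ns2)n1`: 644 ng.h/mL

Among the measured compounds shown here, compound 2 holds the only number so far. Compound 1 has no reported result, so compound 2 cannot yet be ranked against anything.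

Compound 3 `Cc1ccc(Cc2cc(Nc3nc(C)cn4c(-c5cn[nH]c5)cnc34)sn2)nc1` has the same atoms as compound 2, joined differently: 5-methylpyridin-2-yl in place of 3-methylpyridin-2-yl on a saturated chain carbon bound to an aromatic carbon. Here, 5-methylpyridin-2-yl takes the place of 3-methylpyridin-2-yl on a saturated chain carbon bound to an aromatic carbon.

For the measured compounds named here, no measured pair shows what this change does in this assay, so the data suggest no direction, and no step beyond the usual scatter is expected. Going by the values given here, the only anchor is compound 2 at 644 ng.h/mL. The expected step is a 1.1-fold lower number from compound 2 to compound 3 (0.03 log units; within the scatter). In this assay, the estimated value for compound 3 is 600 ng.h/mL, with an expected range of 200 ng.h/mL to 1800 ng.h/mL.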

Compound 3, area under the concentration-time curve: 1370 ng.h/mL
For compound 3 the middle estimate is 2.3-fold (0.36 log units) below the measured one; low and high end bracket the measured number.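

Moving the methyl group around the pyridine ring, with no atom added or lost, is enough to shift the read-out in this assay: 5-methylpyridin-2-yl in place of 3-methylpyridin-2-yl gives a 2.1-fold higher number from compound 2 to compound 3 (0.33 log units; beyond the scatter). Among the compounds shown here, this is the first measured pair here, and it shows that oral exposure depends on where the methyl sits on this ring, not only on which atoms are present. Nothing available bears on why the number rose, so the pair gives a direction and a size but no explanation.

Still open, going by these compounds, is how a plain pyridin-2-yl without the methyl, or a pyridine carrying a methoxy group or a carboxylic acid instead, would compare. One pair also cannot show whether the same move would have this effect on a different core.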